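Spiro Amine in Place of Trifluoromethyl on a Shared Core

The source may report more compounds than this note shows. Statements on the series, on what has been measured and on what is new or still open speak of the compounds shown alone.

Measured compounds:
compound 1, `O=C(Nc1ccnnc1)c1cc(C(F)(F)F)ccc1OCc1ccccc1`, 15.9 nM
compound 2, `CN1CCC(c2ccc(OCc3ccccc3)c(C(=O)Nc3ccnnc3)c2)CC1`, 20 nM

Both numbers come from an assay on Sf9 cells for inhibition of Leucine-rich repeat serine/threonine-protein kinase 2 (Homo sapiens), read by TR-FRET, with stated times of 30 min and 2 h; a higher number here means a weaker inhibitor, a lower number a stronger inhibitor. Compound 1 holds the lowest of the two numbers, but its nearest neighbour, compound 2, lies within the scatter, as the step of a 1.3-fold higher number from compound 1 to compound 2 (0.10 log units; within the scatter) shows, so no order between them can be read. Compound 3, `CN1CC2(CCN(c3ccc(OCc4ccccc4)c(C(=O)Nc4ccnnc4)c3)CC2)C1`, has not been measured. It differs from compound 1 as follows: a group of 10 heavy atoms (8 carbon, 2 nitrogen; one four-membered non-aromatic ring with 1 hetero atom, one six-membered non-aromatic ring with 1 hetero atom) in place of a group of 4 heavy atoms (1 carbon, 3 fluorine; no ring), on an aromatic carbon. Going by the values given here, the one measured step that bears on this change is the one from compound 1 to compound 2, where a ring-bearing nitrogen group likewise replaced the trifluoromethyl on the same aromatic carbon and the number barely moved. Compound 3 is therefore expected to give about 20 nM, estimated to fall between 8 nM and 50 nM. The estimated step of a 1.3-fold higher number from compound 1 to compound 3 (0.10 log units; within the scatter) is expected to stay within the scatter, in either direction.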

Compound 3, half-maximal inhibitory concentration: 63.1 nM
The estimate for compound 3 lay 3.2-fold (0.50 log units) below the measured number, outside the stated range (above it).
By their numbers in this assay, from the lowest: compounds 1 and 2 (each within the scatter of the next); then compound 3.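

At the aromatic carbon para to the benzyloxy group, compound 2 had shown a ring-bearing amine group replacing trifluoromethyl with no readable change in this assay, but compound 3 shows that this does not hold for every such group: a 4.0-fold higher number from compound 1 to compound 3 (0.60 log units; beyond the scatter), and a 3.2-fold higher number from compound 2 to compound 3 (0.50 log units; beyond the scatter). Both steps are modest, so this position still accepts the larger group of compound 3, which reads 63.1 nM. No measurement given here accounts for the difference between the groups of compound 2 and compound 3.

The compounds shown leave open how an open-chain group, such as dimethylamino, or a carboxylic acid would read at this carbon. They also leave open whether these steps would persist with something other than benzyloxy on the shared core.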